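The compounds below may be only part of what the source reports. "The series", "measured", "known", "first", "only" and "open" are said of these compounds alone.

Values in a physicochemical assay; a lower number here means a stronger inhibitor, a higher number a weaker inhibitor:
- compound 1 `O=c1[nH]nc(Cc2ccccc2)n1/N=C/c1ccc(O)c(O)c1`: 0.026 ug/mL
- compound 2 `O=c1[nH]nc(Cc2ccc(Cl)cc2)n1/N=C/c1ccc(O)c(O)c1`: 0.026 ug/mL
- compound 3 `Cc1n[nH]c(=O)n1/N=C/c1ccc(O)c(O)c1`: 0.025 ug/mL

Compound 2 gives 0.026 ug/mL, the same digits as compound 1, and compound 3 sits within the scatter of both. Among the measured compounds shown here, the series therefore shows no separation in this assay so far.

The next compound is compound 4 `COc1ccc(Cc2n[nH]c(=O)n2/N=C/c2ccc(O)c(O)c2)cc1`, which has methoxy in place of chloro on an aromatic carbon of compound 2: methoxy in place of chloro on an aromatic carbon.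

For the measured compounds named here, no measured compound carries methoxy, so this exact change has no direct precedent. Going by the values given here, three measured steps bear on it. Chloro in place of hydrogen on the same ring gave no change at the digits printed from compound 1 to compound 2 (within the scatter). Hydrogen in place of the whole 4-chlorophenyl gave a 1.0-fold lower number from compound 2 to compound 3 (0.02 log units; within the scatter), and hydrogen in place of phenyl gave a 1.0-fold lower number from compound 1 to compound 3 (0.02 log units; within the scatter). All three lie within the scatter, so neither the substituent on this ring nor the ring itself has yet moved the number in this assay. Three compounds are a thin basis, but a swap at the same ring position is expected to behave alike, with no shift beyond the scatter in either direction.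

The expected change is no change at the digits printed from compound 2 to compound 4 (within the scatter). For compound 4 the estimated value is 0.026 ug/mL, with an expected range of 0.018 ug/mL to 0.038 ug/mL.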

Compound 4, half-maximal inhibitory concentration: 0.05 ug/mL
For compound 4 the middle estimate is 1.9-fold (0.28 log units) below the measured one; the measured number lies above the stated range.
By their numbers in this assay, from the lowest: compounds 3, 1, 2 and 4 (each within the scatter of the next).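

In this assay the swap of chloro for methoxy on the aromatic carbon para to a large group gives a 1.9-fold higher number from compound 2 to compound 4 (0.28 log units; within the scatter) and is no longer flat at the digits printed, unlike the earlier change of hydrogen to chloro at the same place. The other two comparisons read alike: 4-methoxyphenyl in place of hydrogen gives a 2.0-fold higher number from compound 3 to compound 4 (0.30 log units; within the scatter) and methoxy in place of hydrogen on the ring gives a 1.9-fold higher number from compound 1 to compound 4 (0.28 log units; within the scatter) as the matching step. These are the largest steps in the series so far, yet all three stay within the scatter, so compound 4 is not separated from compounds 1, 2 and 3, and neither this position nor the methoxy group is shown to control the number.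

As far as these compounds go, whether this position can move the number beyond the scatter remains open, and an amine or a carboxylic acid in place of the methoxy, or a longer chain on its oxygen, would test that. No supporting evidence bears on the origin of these steps.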